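Phenoxy in Place of Sulfonyl: Outlook for Compound 4

The source may report more compounds than this note shows. Statements on the series, on what has been measured and on what is new or still open speak of the compounds shown alone.

Three compounds of the shared core have numbers in a functional assay on CHO.K1 cells for antagonist activity at prostaglandin D2 receptor 2 (Homo sapiens), read by GTPgammaS binding, with a stated time of 1 h; on this read-out higher numbers stand for weaker inhibition and lower numbers for stronger inhibition. Compound 1 `Cc1c(Cc2ccc(C(=O)O)cc2S(=O)(=O)c2ccccc2)c2c(n1CC(=O)O)CCNC2=O` gives 19 nM. Compound 2 `COc1cccc(S(=O)(=O)c2ccccc2Cc2c3c(n(CC(=O)O)c2C)CCNC3=O)c1` gives 12 nM, the second highest of the three; its gap to compound 1 lies within the scatter, so no order between the two is claimed. Compound 3 `Cc1c(Cc2ccc(S(=O)(=O)Cc3ccccc3)cc2)c2c(n1CC(=O)O)CCNC2=O` gives 3 nM, a lower number that stands beyond the scatter from compound 2. Within the data shown here, all three measured compounds carry a sulfonyl group; no compound without one has been measured.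

Compound 4 `Cc1c(Cc2ccccc2Oc2ccccc2)c2c(n1CC(=O)O)CCNC2=O` is not yet measured. It differs from compound 2 in one place: phenoxy in place of (3-methoxyphenyl)sulfonyl on an aromatic carbon. Among the measured compounds shown here, no measured pair shows this change, so its size is not known from data. The step from compound 2 to compound 4 is expected to raise the number beyond the scatter, as the sulfonyl present in every measured compound is removed. Compound 4 is expected at 45 nM, within 10 nM to 250 nM, an expected step of a 3.8-fold higher number from compound 2 to compound 4 (0.57 log units; beyond the scatter).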

Compound 4, half-maximal inhibitory concentration: 530 nM
Compound 4: the middle estimate sits 12-fold (1.07 log units) below what was measured, and the stated range ends below it.
By their numbers in this assay, from the lowest: compound 3; then compounds 2 and 1 (each within the scatter of the next); then compound 4.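

In this assay, phenoxy in place of (3-methoxyphenyl)sulfonyl on an aromatic carbon ortho to a large group gives a 44-fold higher number from compound 2 to compound 4 (1.65 log units; beyond the scatter), a large step beyond the scatter, so this position does not tolerate the change without a clear loss of inhibition. Compound 4 is also the only compound shown without a sulfonyl group, and the change alters more than that group: the substituent goes from 11 heavy atoms to 7 and from 3 hydrogen-bond acceptors to 1, while one aromatic ring stays. No measurement at hand bears on why the number rises.

This single step cannot separate the loss of the sulfonyl from the loss of the methoxy. Open, as far as these compounds go, is how an amine or a sulfonamide would read at this position in place of the phenoxy.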